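This account rests on a few compounds, and the source may have more. Where it says the series, first, only, none or still open, it means among the compounds named here.

Compounds measured so far in an assay on isolated protein for inhibition of cytosolic endo-beta-N-acetylglucosaminidase (Homo sapiens), tested at 1000 uM; on this read-out higher numbers stand for more inhibition at the one concentration tested (going by the name of the read-out) and lower numbers for less inhibition:
compound 1 `O=C(O)[C@H]1NC[C@H](O)[C@@H](O)[C@H]1O` gives 2.6%
compound 2 `O=C(O)[C@@H]1NC[C@@H](O)[C@H](O)[C@H]1O` gives 50%
compound 3 `O=C(O)[C@@H]1NC[C@@H](O)[C@H](O)[C@@H]1O` gives 0.8%

Compound 3 stands lowest of the three numbers in this assay: its nearest neighbour is compound 1, within the scatter, and its furthest is compound 2, beyond the scatter. All three share the same atoms and bonds and differ only in configuration as drawn, which is the whole of what separates them the fact that compounds 1 and 2 differ only in the configuration as drawn the fact that compounds 1 and 3 differ only in the configuration as drawn (the fact that compounds 2 and 3 differ only in the configuration as drawn).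

The next compound is compound 4 `O=C(O)[C@@H]1NC[C@H](O)[C@H](O)[C@H]1O`. Its difference from compound 3 is the two compounds have the same atoms and bonds and differ only in configuration as drawn: 2 of 4 stereo elements differ; a stereocentre at a saturated ring carbon is drawn R in compound 3 and S in compound 4; a stereocentre at a saturated ring carbon is drawn R in compound 3 and S in compound 4.

Within the data shown here, three measured steps bear on configuration changes. A single stereocentre inversion gave a number 49.2 percentage points lower from compound 2 to compound 3 (beyond the scatter). Three inversions gave a number 47.4 percentage points higher from compound 1 to compound 2 (beyond the scatter). Inverting all four centres gave a number 1.8 percentage points lower from compound 1 to compound 3 (within the scatter). The size of a configuration step is therefore not tied to the number of centres changed: one inversion can move the read-out as much as three, and four can leave it where it was. Two inversions from a compound at the floor of the series could leave it there or lift it substantially.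

Estimate for compound 4: 12%, range 0% to 45%, which is expected to mean a number 11.2 percentage points higher from compound 3 to compound 4 (beyond the scatter).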

Compound 4, a percentage reported as inhibition, at one concentration (the size of the read-out at that concentration, not a potency): 39%
The estimate for compound 4 lay 27 percentage points below the measured number, and the stated range covers the measured number.
By their numbers in this assay, from the lowest: compounds 3 and 1 (each within the scatter of the next); then compound 4; then compound 2.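

In this assay, one pair of inversions gives a number 38.2 percentage points higher from compound 3 to compound 4 (beyond the scatter), and a different pair gives a number 36.4 percentage points higher from compound 1 to compound 4 (beyond the scatter), so two changes of configuration can lift the read-out well clear of the low pair. Single inversions at two different centres of the same parent now also read apart: one gives a number 11 percentage points lower from compound 2 to compound 4 (beyond the scatter), a modest step, and the other gives a number 49.2 percentage points lower from compound 2 to compound 3 (beyond the scatter), a large one, which ties the size of a step in these four compounds to which centre is inverted and not to how many. Compound 2 remains the highest of the four, and configuration is the only thing that separates it from the next one up the order: the fact that compounds 2 and 4 differ only in the configuration as drawn.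

Every number here comes from a single concentration, so the series gives no potency and no ranking beyond that one read-out. Still open, from the compounds shown here alone, is whether the inhibition seen with compound 2 survives a methyl ester or an amide in place of the carboxylic acid, or a longer chain on the ring nitrogen.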